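The compounds below may be only part of what the source reports. "The series", "measured", "known", "first", "only" and "open" are said of these compounds alone.

Three compounds of this series have numbers in an assay on membranes from striatum (strain Sprague-Dawley) for displacement of a labelled ligand from sodium-dependent dopamine transporter (Rattus norvegicus), read by scintillation counting, with a stated time of 120 min; on this read-out higher numbers stand for weaker inhibition and lower numbers for stronger inhibition. Compound 1 `O=C(c1cc2ccccc2[nH]1)N1CCC(NCCSC(c2ccc(F)cc2)c2ccc(F)cc2)CC1` gives 177 nM; compound 2 `O=C(c1ccccc1)N1CCC(NCC[S+]([O-])C(c2ccc(F)cc2)c2ccc(F)cc2)CC1` gives 79.1 nM; compound 3 `O=C(c1ccccc1F)N1CCC(NCCSC(c2ccc(F)cc2)c2ccc(F)cc2)CC1` gives 46.1 nM. Compound 2 stands second highest of the three: its nearest neighbour is compound 3, within the scatter, and compound 1 lies furthest from it, beyond the scatter. Within the data shown here, the only single-point step measured, a 3.8-fold lower number from compound 1 to compound 3 (0.58 log units; beyond the scatter), concerns a different exchange on the carbonyl carbon and bears on the present question only loosely. Among the measured compounds shown here, compound 4 `O=C(c1ccccc1F)N1CCC(NCC[S+]([O-])C(c2ccc(F)cc2)c2ccc(F)cc2)CC1` differs from compound 2 by fluoro in place of hydrogen on an aromatic carbon; no measured pair isolates this change. The expectation for compound 4 is therefore a step of a 1.3-fold lower number from compound 2 to compound 4 (0.12 log units; within the scatter), not beyond the scatter, giving an estimated 60 nM with a range from 25 nM to 150 nM.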

Compound 4, inhibition constant: 604 nM
For compound 4 the middle estimate is 10-fold (1.00 log units) below the measured one, outside the stated range (above it).
By their numbers in this assay, from the lowest: compounds 3 and 2 (each within the scatter of the next); then compound 1; then compound 4.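

In this assay this position is not indifferent to a single added atom on the sulfoxide: a 7.6-fold higher number from compound 2 to compound 4 (0.88 log units; beyond the scatter). Compound 3, with the same 2-fluorophenyl on the sulfide, gives 46.1 nM, so 2-fluorophenyl does not by itself go with a high number. Nothing shown accounts for this step.

Open, on these data alone, is how large the same fluoro step is on the sulfide. Also open, as far as these compounds go, is whether chloro or methoxy in place of fluoro at this position would follow compound 4.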